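Methyl in Place of Hydrogen on the Acid of Compound 3

The source may hold more compounds than are shown below. What is called first, only, known or untested is meant among the compounds shown, and "the series" means these compounds.

Compound 1 `NNC(=O)COc1ccncc1-c1ccc2ccccc2c1`: 19%
Compound 2 `CCOC(=O)/C=C/c1ccncc1-c1ccc2ccccc2c1`: 102%
Compound 3 `O=C(O)/C=C/c1ccncc1-c1ccc2ccccc2c1`: 102%

Of the compounds shown here, three sharing one core have been measured in an assay on a protein complex for inhibition of CDK8/Cyclin C (Homo sapiens), with a stated time of 1 h, tested at 10 uM; a lower number here means less inhibition, a higher number more inhibition at the concentration tested (going by the name of the read-out). Compound 1 gives 19%. Compound 2 gives 102%, and compound 3 gives 102%. Compound 3 therefore stands level with compound 2, the two together being the highest of the three numbers, while the step of a number 83 percentage points higher from compound 1 to compound 3 (beyond the scatter) separates compound 3 from compound 1.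

Compound 4 `COC(=O)/C=C/c1ccncc1-c1ccc2ccccc2c1` is the next compound. Its difference from compound 3 is methyl in place of hydrogen on an oxygen next to a carbonyl group. Among the measured compounds shown here, the one measured step that bears on this is no change at the digits printed from compound 2 to compound 3 (within the scatter), where ethyl on that same oxygen was exchanged for hydrogen without any shift. Putting a methyl on that oxygen is the same kind of change in the opposite direction, with a smaller group. The expected step is therefore none beyond the scatter, no change at the digits printed from compound 3 to compound 4 (within the scatter). For compound 4 the estimated value in this assay is 102%, within a range from 90% to 110%.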

Compound 4, a percentage reported as inhibition, at one concentration (the size of the read-out at that concentration, not a potency): 102%
Estimate against measurement, compound 4: no gap at the digits printed; low and high end bracket the measured number.
By their numbers in this assay, from the lowest: compound 1; then compounds 2, 3 and 4 (each within the scatter of the next).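

In this assay, the oxygen next to the carbonyl group has now carried hydrogen, methyl and ethyl with no separation in the read-out: no change at the digits printed from compound 3 to compound 4 (within the scatter), and no change at the digits printed from compound 2 to compound 4 (within the scatter). The large gap to the shared core bearing (aminocarbamoyl)methoxy also holds for the methyl ester, a number 83 percentage points higher from compound 1 to compound 4 (beyond the scatter), so among these compounds only that one differs clearly from the rest. No measurement here explains why the group on this oxygen makes no difference to the number.

As far as these compounds go, whether a primary amide in place of the ester, or a longer chain such as butyl on that oxygen, would also leave the number unchanged stays open. These are readings at a single concentration rather than potencies, so compound 2, compound 3 and compound 4 could still differ at lower concentrations.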